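Stereo inversion on the dichloro urea of compound 3

The compounds below may be only part of what the source reports. "The series", "measured", "known", "first", "only" and "open" are said of these compounds alone.

Measured so far in an ADME assay on the whole organism with Oryza sativa as the target, tested at 1 uM; a lower number here means a stronger effect, a higher number a weaker effect of the compound at the concentration tested:
- compound 1 `C[C@@H](NC(=O)Nc1cccc(Cl)c1)c1ccccc1` gives 91%
- compound 2 `C[C@H](NC(=O)Nc1cccc(Cl)c1)c1ccccc1` gives 99%
- compound 3 `C[C@@H](NC(=O)Nc1cc(Cl)cc(Cl)c1)c1ccccc1` gives 99%

Compound 3 stands level with compound 2 at the digits reported, the two together giving the highest numbers of the three in this assay; compound 1 lies lowest, though a number 8 percentage points higher from compound 1 to compound 3 (within the scatter) keeps that gap inside the usual scatter. Compound 3 carries a chloro in place of hydrogen on an aromatic carbon relative to compound 1, and that single change is all that separates them.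

The step now in question leads to compound 4 `C[C@H](NC(=O)Nc1cc(Cl)cc(Cl)c1)c1ccccc1`. Here the two compounds have the same atoms and bonds and differ only in configuration as drawn: 1 of 1 stereo elements differ; a stereocentre at a saturated chain carbon is drawn R in compound 3 and S in compound 4 The one measured step that speaks to this is the pair of compounds 1 and 2, which also differ only in configuration as drawn (the fact that compounds 1 and 2 differ only in the configuration as drawn), and there a number 8 percentage points higher from compound 1 to compound 2 (within the scatter). Nothing beyond the scatter followed from inverting the drawn stereocentre in that pair, so no move beyond the scatter is expected for this assay on going from compound 3 to compound 4 either: the estimated step is a number 1 percentage points lower from compound 3 to compound 4 (within the scatter).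

For compound 4 the expected value in this assay is therefore 98%, with a range from 88% to 105%.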

Compound 4, a percentage reported as activity, at one concentration (the size of the read-out at that concentration, not a potency): 100%
Beside the measured number, compound 4's estimate is 2 percentage points below it; the range from low to high includes it.
By their numbers in this assay, from the lowest: compounds 1, 2, 3 and 4 (each within the scatter of the next).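

Inverting the stereocentre at the saturated chain carbon can now be read on a second core in this assay, and the step is a number 1 percentage points higher from compound 3 to compound 4 (within the scatter), so neither pair of mirror-drawn compounds shows a move beyond the scatter: the fact that compounds 3 and 4 differ only in the configuration as drawn. The chloro in place of hydrogen on an aromatic carbon can also now be read with the stereocentre drawn S, where the step is a number 1 percentage points higher from compound 2 to compound 4 (within the scatter), and the two readings of this change agree: the same change on two cores in this assay, a number 8 percentage points higher (within the scatter) from compound 1 to compound 3 and a number 1 percentage points higher (within the scatter) from compound 2 to compound 4, 7 percentage points apart, within the scatter of two such steps. Within these four compounds, then, neither the drawn configuration nor this added chloro, on either core, gives a step beyond the scatter.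

Going by these compounds, whether any change to this urea moves the number beyond the scatter stays open. A carboxylic acid or an amine in place of chloro, or a longer chain at the stereocentre, would address that.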